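This account rests on a few compounds, and the source may have more. Where it says the series, first, only, none or still open, it means among the compounds named here.

Measured so far:
compound 1 `CC1=C(C(=O)OC(C)C(F)(F)F)C(c2ccco2)NC(=O)N1`: 11%; 7% (2 entries)
compound 2 `CC1=C(C(=O)OCC(F)(F)F)C(c2ccsc2)NC(=O)N1`: 1%
compound 3 `CC1=C(C(=O)OCC(F)(F)F)C(c2ccoc2)NC(=O)N1`: 1%

In an assay on HeLa cells for displacement of a labelled ligand from adenosine receptor A3 (Homo sapiens), read by radioligand binding, with a stated time of 180 min, tested at 1 uM (a lower number here means less inhibition, a higher number more inhibition at the concentration tested (going by the name of the read-out)), compound 3 gives 1%, level with compound 2 at the digits shown. Going by the values given here, the only measured step, no change at the digits printed from compound 2 to compound 3 (within the scatter), stays within the scatter. Compound 4 `CC1=C(C(=O)OCC(F)(F)F)C(c2ccco2)NC(=O)N1` differs from compound 3 by furan-2-yl in place of furan-3-yl on a saturated ring carbon. Among the compounds with values here, no measured step turns one furan into the other, so that step does not bear directly on the change; compound 1, which carries furan-2-yl with a different ester, gives 11%; 7% (2 entries) in this assay (the several entries of compound 1 in this assay, 11%; 7% (2 entries)), also a low reading. Compound 4 is therefore expected to give 5%, between 0% and 15%. The step of a number 4 percentage points higher from compound 3 to compound 4 (within the scatter) is expected to stay within the scatter.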

Compound 4, a percentage reported as inhibition, at one concentration (the size of the read-out at that concentration, not a potency): 1%
For compound 4 the middle estimate is 4 percentage points above the measured one; the range from low to high includes it.
By their numbers in this assay, from the lowest: compounds 2, 3 and 4 (each within the scatter of the next).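

Replacing furan-3-yl with furan-2-yl on a saturated ring carbon gives no change at the digits printed from compound 3 to compound 4 (within the scatter) in this assay. Replacing thiophen-3-yl with furan-2-yl likewise gives no change at the digits printed from compound 2 to compound 4 (within the scatter). With this ester, the three five-membered aromatic rings therefore read alike at this position, and the furan's point of attachment makes no visible difference.

On these data alone, whether a phenyl ring or an aminomethyl group on this carbon would read differently remains open. So does the role of the ester, the one place where compound 1 differs from compound 4: the several entries of compound 1 in this assay, 11%; 7% (2 entries)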